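The source may report more compounds than this note shows. Statements on the series, on what has been measured and on what is new or still open speak of the compounds shown alone.

Measured so far in a functional assay on PC-3 cells (Homo sapiens) for cytotoxicity, read by MTT assay, with a stated time of 48 h; on this read-out higher numbers stand for weaker inhibition and lower numbers for stronger inhibition:

Compound 1 `OC[C@@H]1C[C@H](CO)[C@@H]2C(c3ccc(Cl)cc3)=NO[C@H]12` gives > 50 ug/mL, a limit of the assay.

Compound 2 `Cc1ccc(C2=NO[C@@H]3[C@H](CO)C[C@H](CO)[C@H]23)cc1` gives 28 ug/mL.

Compound 3 `OC[C@@H]1C[C@H](CO)[C@@H]2C(c3ccc(Br)cc3)=NO[C@H]12` gives > 50 ug/mL, a limit of the assay.

Compound 3 therefore stands only at a limit, and so does compound 1 (the limit of > 50 ug/mL in this assay, at which 2 of the 3 values shown sit); compound 2 alone has a number. Compound 4 `N#Cc1ccc(C2=NO[C@@H]3[C@H](CO)C[C@H](CO)[C@H]23)cc1` differs from compound 3 by cyano in place of bromo on an aromatic carbon. Among the measured compounds shown here, no measured step swaps bromo for cyano. The nearest steps are an at least 1.7-fold higher number from compound 2 to compound 3 (0.25 log units; that floor lies within the scatter) and an at least 1.7-fold lower number from compound 1 to compound 2 (0.25 log units; that floor lies within the scatter), both small, while a step that the two limits leave unreadable from compound 1 to compound 3. With no readable pull in either direction, compound 4 is expected to stay close to compound 3, and the step of an at least 1.2-fold lower number from compound 3 to compound 4 (0.09 log units; that floor lies within the scatter) is estimated as small. Compound 4 is expected to give 40 ug/mL, with a range from 15 ug/mL to 100 ug/mL.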

Compound 4, half-maximal inhibitory concentration: > 50 ug/mL
Compound 4: a limit, no number (the forecaster's own chance of this, stated with the estimate: 50%); middle value at least 1.2-fold (0.09 log units) away from the limit.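

In this assay, among the compounds shown here, the cyano group joins chloro and bromo on this aromatic carbon at the limit, leaving the methyl group of compound 2 as the only one with a number: the limit of > 50 ug/mL in this assay, at which 3 of the 4 values shown sit. For the compounds shown here, the one step that can be read is an at least 1.7-fold higher number from compound 2 to compound 4 (0.25 log units; that floor lies within the scatter). The steps among compound 1, compound 3 and compound 4 cannot be read, as all three stand at the limit.

Still open, on these data alone, is how far compound 1, compound 3 and compound 4 differ from one another. Also open, as far as these compounds go, is whether an amine, a methoxy group or a longer chain at this place would give a number, and on which side of compound 2 it would fall.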